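Kinetic solubility across four amine substituents

The source may report more compounds than this note shows. Statements on the series, on what has been measured and on what is new or still open speak of the compounds shown alone.

Measured so far in a physicochemical assay for solubility, read by HPLC, using the shake flask method, measured as kinetic solubility, with a stated time of 2 h, at pH 7.4; a lower number here means a less soluble compound, a higher number a more soluble compound:
Compound 1, `Cc1cc(Nc2ccccn2)n2nc(C)c(-c3ccccc3)c2n1`, gives < 5000 nM, which is a limit of the assay.
Compound 2, `Cc1cc(NCc2nccn2C)n2nc(C)c(-c3ccccc3)c2n1`, gives 26900 nM.
Compound 3, `Cc1cc(NCc2ncc[nH]2)n2nc(C)c(-c3ccccc3)c2n1`, gives < 5000 nM, again a limit of the assay.

Compound 3 thus stands at the floor of what this assay reports, and only a limit is known for it; it shares that position with one other compound, as the limit of < 5000 nM in this assay, at which 2 of the 3 values shown sit, shows. Compound 4, `Cc1cccc(CNc2cc(C)nc3c(-c4ccccc4)c(C)nn23)n1`, has not yet been measured. It differs from compound 3 in one place: 6-methylpyridin-2-yl in place of 1H-imidazol-2-yl on a saturated chain carbon bound to a nitrogen on an aromatic ring.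

Within the data shown here, two measured steps bear on this change. an at least 5.3-fold higher number from compound 1 to compound 2 (0.73 log units; beyond the scatter), and an at least 5.3-fold lower number from compound 2 to compound 3 (0.73 log units; beyond the scatter); between them, a step that the two limits leave unreadable from compound 1 to compound 3. Among the measured compounds shown here, the one number above the limit belongs to compound 2, which carries the methyl on the imidazole nitrogen, while compound 1 with the pyridin-2-yl and compound 3 with the bare imidazole both sit at the limit. Compound 4 carries a 6-methylpyridin-2-yl and no ring nitrogen hydrogen, so no step beyond the scatter is expected in this assay. Compound 4 is therefore estimated at 5000 nM, with an expected range from 2000 nM to 20000 nM, meaning a number no lower from compound 3 to compound 4 (the limit leaves the size open).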

Compound 4, solubility: < 5000 nM
Compound 4 ended at the assay's limit; the forecaster's own chance of this, stated with the estimate: 60%; the middle value sits exactly at the limit.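

The new value gives a second readable comparison with compound 2: in this assay there is an at least 5.3-fold lower number from compound 2 to compound 4 (0.73 log units; beyond the scatter), with 6-methylpyridin-2-yl in place of 1-methyl-1H-imidazol-2-yl on a saturated chain carbon bound to a nitrogen on an aromatic ring. Compound 2 therefore remains the only one of the four with a number that is not a limit, and the absence of a hydrogen-bond donor in the entering group of compound 4 does not set that compound apart from compound 3, whose group has one. The steps from compound 3 to compound 4 and from compound 1 to compound 4 cannot be read, and the limit now holds most of the set: the limit of < 5000 nM in this assay, at which 3 of the 4 values shown sit.

Going by these compounds, how far compound 1, compound 3 and compound 4 lie beyond that limit remains unknown, so they cannot be placed in any order. Also open, on these data alone, is whether the higher number of compound 2 is tied to the 1-methyl-1H-imidazol-2-yl group, or whether another group in the same place, such as a morpholine or a carboxylic acid, would also leave the limit.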